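The source may hold more compounds than are shown below. What is called first, only, known or untested is meant among the compounds shown, and "the series" means these compounds.

For the measured compounds named here, only two compounds with this shared core have numbers so far in a functional assay on KB cells (Homo sapiens) for cytotoxicity (a lower number here means a stronger inhibitor, a higher number a weaker inhibitor), and they lie well apart. Compound 1 `COc1ccc(S(=O)(=O)N2CCc3cccc(NS(=O)(=O)c4ccc(F)cc4)c32)cc1` reads 1200 nM and compound 2 `COc1ccc(S(=O)(=O)N2CCc3cccc(NC(=O)c4ccc(C#N)cc4)c32)cc1` reads 105 nM as the lower of the two numbers. Going by the values given here, the one measured step is large and beyond the scatter: an 11-fold lower number from compound 1 to compound 2 (1.06 log units; beyond the scatter) and it came with (4-cyanophenyl)carbonyl in place of (4-fluorophenyl)sulfonyl on a nitrogen on an aromatic ring. Compound 3 `COc1ccc(S(=O)(=O)N2CCc3cccc(NC(=O)N(C)c4ccccc4)c32)cc1` has not yet been measured. It differs from compound 2 in one place: methyl(phenyl)amino in place of 4-cyanophenyl on a carbonyl carbon with methyl(phenyl)amino in place of 4-cyanophenyl on a carbonyl carbon. The carbonyl stays, so compound 3 keeps the feature that compound 2 gained in an 11-fold lower number from compound 1 to compound 2 (1.06 log units; beyond the scatter) as its number fell. Among the compounds with values here, no measured step replaces 4-cyanophenyl itself, so the direction rests on thin evidence. A moderate step toward a higher number is expected, smaller than the one already seen. The estimated change is a 2.9-fold higher number from compound 2 to compound 3 (0.46 log units; beyond the scatter) and it carries wide uncertainty. Compound 3 is expected at 300 nM in this assay with an estimated range from 60 nM to 1500 nM for the measurement.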

Compound 3, half-maximal inhibitory concentration: > 10000 nM
Compound 3: a limit, no number; the forecaster's own chance of this, stated with the estimate: 5%; middle value at least 33-fold (1.52 log units) away from the limit.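

In this assay, compound 3 gives only a limit, > 10000 nM, and not a number. That limit still fixes a direction: methyl(phenyl)amino in place of 4-cyanophenyl on a carbonyl carbon brought an at least 95-fold higher number from compound 2 to compound 3 (1.97 log units; beyond the scatter), so keeping the carbonyl does not by itself hold the number low, and the group on that carbon decides much of the outcome. Methyl(phenyl)carbamoyl in place of (4-fluorophenyl)sulfonyl on a nitrogen on an aromatic ring also brought an at least 8.3-fold higher number from compound 1 to compound 3 (0.92 log units; beyond the scatter), so among these three compounds the carbonyl-bearing replacement can lie on either side of the sulfonyl, with compound 2 on the low side and compound 3 on the high side.

On these data alone, how far the true value of compound 3 lies past its limit stays unknown, so the full size of both steps remains open. Also open is which part of the change matters: phenyl alone on the carbonyl carbon would test the loss of the nitrile, while phenylamino would test the methyl on the entering nitrogen, and the compounds shown separate neither.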